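Methoxy in Place of Methyl: Expectation for Compound 3

The source may report more compounds than this note shows. Statements on the series, on what has been measured and on what is new or still open speak of the compounds shown alone.

Of the compounds shown here, two sharing a core have been measured in an assay on CHO cells for displacement of a labelled ligand from prostaglandin E2 receptor EP3 subtype (Mus musculus), read by scintillation counting, with a stated time of 60 min; on this read-out higher numbers stand for weaker inhibition and lower numbers for stronger inhibition. Compound 1 `O=C(O)CCCSCCN1C(=O)SC[C@@H]1/C=C/[C@@H](O)Cc1ccccc1` gives 39 nM. Compound 2 `CCc1cccc(C[C@H](O)/C=C/[C@H]2CSC(=O)N2CCSCCCC(=O)O)c1` gives 65 nM, the higher of the two numbers, though the step of a 1.7-fold higher number from compound 1 to compound 2 (0.22 log units; within the scatter), made by putting ethyl in place of hydrogen on an aromatic carbon, is within the scatter, so the two compounds cannot be ordered.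

Compound 3 `COCc1cccc(C[C@H](O)/C=C/[C@H]2CSC(=O)N2CCSCCCC(=O)O)c1` has not yet been measured. It differs from compound 2 by methoxy in place of methyl on a saturated chain carbon bound to an aromatic carbon. Among the measured compounds shown here, no measured pair shows this change, so the only guide is that the one step on record at this part of the molecule, from compound 1 to compound 2, stayed within the scatter. A change of similar size at the same region is therefore expected to stay within the scatter as well, and the step of a 1.1-fold higher number from compound 2 to compound 3 (0.03 log units; within the scatter) is estimated to be small and of uncertain direction. In this assay compound 3 is expected to give about 70 nM, with a range from 25 nM to 200 nM.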

Compound 3, inhibition constant: > 10000 nM
Compound 3: no number, only a limit; the forecaster's own chance of this, stated with the estimate: 2%; middle value at least 140-fold (2.15 log units) away from the limit.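

In this assay compound 3 gives no number, only a limit of the assay: the limit of > 10000 nM in this assay, at which 1 of the 3 values shown sits.

Until now the one change on record at this part of the molecule, a 1.7-fold higher number from compound 1 to compound 2 (0.22 log units; within the scatter), with ethyl in place of hydrogen on an aromatic carbon, had shown no measurable effect. Methoxy in place of methyl on a saturated chain carbon bound to an aromatic carbon now gives an at least 150-fold higher number from compound 2 to compound 3 (2.18 log units; beyond the scatter), so a change at the far end of that substituent can matter far more than the earlier step suggested. Methoxymethyl in place of hydrogen on an aromatic carbon likewise gives an at least 250-fold higher number from compound 1 to compound 3 (2.40 log units; beyond the scatter), which shows that this place accepts ethyl but that the 3-(methoxymethyl)phenyl compound falls far behind both earlier compounds.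

The true size of both large steps stays unknown, and the compounds shown cannot say whether the oxygen itself or the longer chain is what matters. As far as these compounds go, it also stays open whether a hydroxymethyl group, an amine or a propyl chain at the same place would behave like ethyl or like methoxymethyl.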